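The compounds below may be only part of what the source reports. "The series", "measured", "known", "first", "only" and "open" are said of these compounds alone.

Compound 1 `CCCCOc1ccc(C(CC(=O)O)c2ccccc2)cc1` — 1.2 uM
Compound 2 `CCCCOc1ccc(C(CC(=O)O)c2cccc(F)c2)cc1` — 1.44 uM

In a functional assay on HEK293 cells for agonist activity at Free fatty acid receptor 1 (Homo sapiens), read by calcium flux (on this read-out lower numbers stand for an effect already at smaller amounts and higher numbers for an effect only at larger amounts of compound), compound 2 stands highest of the two numbers, with compound 1 nearest at a 1.2-fold higher number from compound 1 to compound 2 (0.08 log units; within the scatter). Compound 3 `CCCCOc1ccc(C(CC(=O)O)c2cccs2)cc1` carries thiophen-2-yl in place of 3-fluorophenyl on a saturated chain carbon bound to an aromatic carbon and a saturated chain carbon. Within the data shown here, only the step from compound 1 to compound 2 bears on this change, and it stayed within the scatter, so the replacement of one aromatic ring on the same chain carbon by another gives no footing for a shift in either direction. The expected outcome for compound 3 is therefore a step of a 1.0-fold higher number from compound 2 to compound 3 (0.02 log units; within the scatter), with compound 3 estimated at 1.5 uM in this assay, ranging from 0.6 uM to 4 uM.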

Compound 3, concentration for half-maximal effect: 1.29 uM
Compound 3: middle estimate off by 1.2-fold (0.07 log units), on the high side; low and high end bracket the measured number.
By their numbers in this assay, from the lowest: compounds 1, 3 and 2 (each within the scatter of the next).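

On the saturated chain carbon bound to an aromatic carbon and a saturated chain carbon, a five-membered aromatic ring with a sulfur atom now takes the place of a six-membered one. In this assay thiophen-2-yl in place of 3-fluorophenyl gives a 1.1-fold lower number from compound 2 to compound 3 (0.05 log units; within the scatter) and thiophen-2-yl in place of phenyl gives a 1.1-fold higher number from compound 1 to compound 3 (0.03 log units; within the scatter) so ring size and the sulfur atom leave the read-out within the scatter across these compounds. No measurement at hand accounts for this result.

On these data alone, whether a pyridin-3-yl ring, a cyclohexyl ring or an amine on this carbon would keep the number stays open. So does what any group here would need to move it beyond the scatter.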